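Exchanging one aromatic group on compound 3

The source may report more compounds than this note shows. Statements on the series, on what has been measured and on what is new or still open speak of the compounds shown alone.

In a functional assay on MCF7 cells (Homo sapiens) for antiproliferative activity, read by CellTiter-Glo, with a stated time of 5 days (a lower number here means a stronger inhibitor, a higher number a weaker inhibitor), compound 1 `CC/C(=C(/c1ccc(/C=C/C(=O)O)cc1)c1ccc2nncn2c1)c1ccccc1` gives > 500 nM, which is a limit and not a number. Compound 2 `CC/C(=C(/c1ccc(/C=C/C(=O)O)cc1)c1ccc2nnnn2c1)c1ccccc1` also gives only a limit, > 500 nM. Among the compounds with values here, compound 3 `N#Cc1ccc(/C(=C(\c2ccc(/C=C/C(=O)O)cc2)c2ccc3scnc3c2)C2CCC2)c(Cl)c1` reads 1.4 nM, the only true number in the set. Compound 4 `O=C(O)/C=C/c1ccc(/C(=C(\c2ncc(C(F)(F)F)cc2Cl)C2CCC2)c2ccc3scnc3c2)cc1` changes a single group of compound 3: 3-chloro-5-(trifluoromethyl)pyridin-2-yl in place of 2-chloro-4-cyanophenyl on a double-bonded chain carbon bound to a double-bonded chain carbon and a saturated ring carbon. Within the data shown here, the one measured step, a step that the two limits leave unreadable from compound 1 to compound 2, lies at another place and cannot be sized, so it offers no guide to this exchange. Among the measured compounds shown here, with no measured step to lean on, a modest loss is expected from compound 3 at 1.4 nM, with wide uncertainty. The estimated change is a 2.9-fold higher number from compound 3 to compound 4 (0.46 log units; beyond the scatter), towards weaker inhibition. Compound 4 is estimated at 4 nM, with an expected range of 0.8 nM to 25 nM.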

Compound 4, half-maximal inhibitory concentration: 2.9 nM
Estimate against measurement, compound 4: 1.4-fold (0.14 log units) above; low and high end bracket the measured number.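

In this assay, this exchange gives the only step of readable size among the compounds shown: a 2.1-fold higher number from compound 3 to compound 4 (0.32 log units; beyond the scatter). At this place, 3-chloro-5-(trifluoromethyl)pyridin-2-yl stands in for 2-chloro-4-cyanophenyl at a modest cost, and compound 4 still reads 2.9 nM. The step between compound 1 and compound 2 cannot be read, as both values are limits: the limit of > 500 nM in this assay, at which 2 of the 4 values shown sit.

From the compounds shown here alone, the separate shares of the ring nitrogen and the trifluoromethyl in this step remain open. So does how an unsubstituted phenyl or an amine would read at this place.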